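The source may hold more compounds than are shown below. What is called first, only, known or untested is meant among the compounds shown, and "the series" means these compounds.

Compound 1 `COc1cc(OC)c(OC)cc1/C=N/n1c(S)nnc1-c1cnccn1`: 143000 nM
Compound 2 `Cc1ccc(/C=N/n2c(S)nnc2-c2cnccn2)cc1`: 156000 nM
Compound 3 `COc1ccccc1/C=N/n1c(S)nnc1-c1cnccn1`: 173000 nM

All three were tested in an ADME assay on NIH3T3 cells (Mus musculus) for cytotoxicity, read by MTT assay, with a stated time of 24 h; on this read-out lower numbers stand for stronger inhibition and higher numbers for weaker inhibition. Compound 2 gives the second highest of the three numbers; its nearest neighbour is compound 1 and its furthest is compound 3, and both gaps lie within the scatter, so the three cannot be separated on this read-out. Compound 4 `Oc1cccc(/C=N/n2c(S)nnc2-c2cnccn2)c1` has not yet been measured in this assay. It differs from compound 2 in one place: 3-hydroxyphenyl in place of 4-methylphenyl on a carbon with a double bond to nitrogen. For the measured compounds named here, no measured pair isolates this change, so there is no measured guide to its size. Since the measured values sit close together, compound 4 is expected to stay near them, an expected step of a 1.0-fold lower number from compound 2 to compound 4 (0.00 log units; within the scatter), meaning nothing beyond the scatter. The estimate for compound 4 in this assay is 155000 nM, within a range from 70000 nM to 340000 nM.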

Compound 4, half-maximal inhibitory concentration: 151000 nM
Estimate against measurement, compound 4: 1.0-fold (0.01 log units) above; the measured number falls inside the stated range.
By their numbers in this assay, from the lowest: compounds 1, 4, 2 and 3 (each within the scatter of the next).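

In this assay, putting 3-hydroxyphenyl in place of 4-methylphenyl on a carbon with a double bond to nitrogen gives a 1.0-fold lower number from compound 2 to compound 4 (0.01 log units; within the scatter) and is the only single-place comparison shown here. At this position, then, the change adds a hydrogen-bond donor and acceptor without a step beyond the scatter. No supporting measurement offers an explanation for this result. The compounds shown leave open whether an amine or a carboxylic acid on this ring would give a step beyond the scatter. They also leave open what a longer chain in place of the ring would do.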